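The source may report more compounds than this note shows. Statements on the series, on what has been measured and on what is new or still open speak of the compounds shown alone.

Measured so far:
- Compound 3 (`COc1ccc(/C(Cl)=C/C=C(\C#N)C(=O)c2c[nH]c3ccccc23)cc1`): > 100000 nM, a limit of the assay, not a number.
- Compound 1 (`COc1cc(/C(Cl)=C/C=C(\C#N)C(=O)c2c[nH]c3ccccc23)cc(OC)c1OC`): 94300 nM
- Compound 2 (`COc1ccc2[nH]cc(C(=O)/C(C#N)=C/C=C(\Cl)c3ccc(OC)c(OC)c3)c2c1`): > 100000 nM, again a limit.

As far as these compounds go, in a functional assay on MCF7 cells (Homo sapiens) for cytotoxicity, read by sulforhodamine B assay, with a stated time of 48 h (a lower number here means a stronger inhibitor of growth, a higher number a weaker inhibitor of growth), compound 3 therefore stands at the limit of > 100000 nM in this assay, at which 2 of the 3 values shown sit, so its true potency is unknown beyond being weak. Compound 4 (`COc1ccc(/C(Cl)=C/C=C(\C#N)C(=O)c2c[nH]c3ccccc23)cc1OC`) carries methoxy in place of hydrogen on an aromatic carbon. Among the compounds with values here, no measured pair shows this exact change, and compound 1, which carries a further methoxy group, sits close to the same limit in this assay. A step from compound 3 to compound 4 beyond the usual scatter is therefore not expected in either direction. For compound 4 the expected value is 100000 nM, within 40000 nM to 250000 nM, so the estimated step of a number no higher from compound 3 to compound 4 (the limit leaves the size open) is essentially none.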

Compound 4, concentration for total growth inhibition: > 100000 nM
Compound 4 was reported as a limit; the forecaster's own chance of this, stated with the estimate: 60%; the middle value lies on the limit itself.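

In this assay, a second methoxy group at this place, ortho to a methoxy group, leaves compound 4 at a limit of the assay rather than giving a number. Taking a methoxy group away gives an at least 1.0-fold higher number from compound 1 to compound 4 (0.02 log units; that floor lies within the scatter), and the other two steps to compound 4 cannot be read. This change therefore shows no gain in growth inhibition, and the compounds remain crowded at one end of the range: the limit of > 100000 nM in this assay, at which 3 of the 4 values shown sit.

As far as these compounds go, whether compound 2, compound 3 and compound 4 differ from one another at all stays open. So does whether an amine or a carboxylic acid on this aromatic carbon would give a readable number.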